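A few compounds are considered here, and "the series" means these few. Any claim that something is new, unique, unknown or untested is made for them only; others in the source may bear on it.

Two close relatives of one peptide-like scaffold have been tested in an assay on isolated protein for inhibition of Trypsin (Homo sapiens), read by fluorescence, with a stated time of 15 min, tested at 50 uM; a higher number here means more inhibition at the concentration tested (going by the name of the read-out), a lower number less inhibition. Compound 1, with structure `C[C@](NC(=O)[C@H](CCCCN)NC(=O)[C@H](CCCNC(=N)N)NC(=O)c1ccccc1)(C(N)=O)c1ccccc1`, gives 11.8% in this assay. Compound 2, with structure `N=C(N)NCCC[C@H](NC(=O)c1ccccc1)C(=O)N[C@@H](CCCCN)C(=O)NC(C(N)=O)(c1ccccc1)c1ccccc1`, gives 45.5% in this assay and so holds the higher of the two numbers, with compound 1 sitting well below it by a gap larger than the usual scatter of repeated runs.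

The next compound, compound 3, with structure `CCC(NC(=O)[C@H](CCCCN)NC(=O)[C@H](CCCNC(=N)N)NC(=O)c1ccccc1)(C(N)=O)c1ccccc1`, has not yet been measured. It differs from compound 2 in one place: ethyl in place of phenyl on a saturated chain carbon bound to an amide-type nitrogen, an aromatic carbon and a carbonyl carbon. Compound 1 carries methyl at the same place, and its low number makes a drop plausible when a second flat aromatic group at that carbon is exchanged for a short chain.

For compound 3, the step of a number 25.5 percentage points lower from compound 2 to compound 3 (beyond the scatter) is therefore expected to run downward, and to be larger than the scatter, because compound 1 gives only 11.8%. Compound 3 is expected to give about 20% in this assay, most likely within the range from 6% to 36%.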

Compound 3, a percentage reported as inhibition, at one concentration (the size of the read-out at that concentration, not a potency): 8.7%
Beside the measured number, compound 3's estimate is 11.3 percentage points above it, within the range that was stated.
By their numbers in this assay, from the lowest: compounds 3 and 1 (each within the scatter of the next); then compound 2.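

In this assay, the loss of phenyl and the entry of ethyl give a number 36.8 percentage points lower from compound 2 to compound 3 (beyond the scatter) and thus show directly that the number depends strongly on which of these two groups sits at this place. The length of the short chain, by contrast, makes no readable difference here: 1-carbamoyl-1-phenylpropyl in place of 1-carbamoyl-1-phenylethyl on an amide-type nitrogen gives a number 3.1 percentage points lower from compound 1 to compound 3 (within the scatter) and so methyl and ethyl cannot be told apart in this read-out. The data shown offer no independent measurement that could explain either step.

Phenyl and ethyl differ both in having an aromatic ring and in their number of carbons, so these two compounds cannot show which of the two differences matters, and a cyclohexyl group at the same carbon would help to separate them. Going by these compounds, it also remains open how a longer chain such as butyl, or a chain ending in an amine or a carboxylic acid, would behave at this place.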